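Fluoro in Place of Trifluoromethyl: What to Expect

This account rests on a few compounds, and the source may have more. Where it says the series, first, only, none or still open, it means among the compounds named here.

Compound 1 `CN1CCC/C1=N\C(=O)Nc1cccc(C(F)(F)F)c1`: > 25 mg/kg
Compound 2 `CN1CCC/C1=N\C(=O)Nc1c(Br)cccc1Br`: > 25 mg/kg

In a functional assay on the whole organism with Rattus norvegicus as the target, with a stated time of 5 days (on this read-out lower numbers stand for an effect already at smaller amounts and higher numbers for an effect only at larger amounts of compound), both measured values are limits of the assay, not numbers. As far as these compounds go, compound 1 stands at the limit of > 25 mg/kg in this assay, at which 2 of the 2 values shown sit, so its true value is unknown beyond that limit. Compound 3 `CN1CCC/C1=N\C(=O)Nc1cccc(F)c1` has not been measured; it differs from compound 1 by fluoro in place of trifluoromethyl on an aromatic carbon. Within the data shown here, no measured pair shows this change, so the expected step in this assay is none beyond the usual scatter. The step of a number no higher from compound 1 to compound 3 (the limit leaves the size open) is expected to be small. Compound 3 is estimated to give 25 mg/kg, in a range from 10 mg/kg to 60 mg/kg, most likely again as a limit.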

Compound 3, minimum effective dose: 25 mg/kg
Beside the measured number, compound 3's estimate shows no gap at the digits printed; the measured number falls inside the stated range.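

In this assay compound 3 gives 25 mg/kg, the first result here that is a number and not a limit. Fluoro in place of trifluoromethyl on this aromatic carbon gives a number no higher from compound 1 to compound 3 (the limit leaves the size open), so the size of this step cannot be read. Most of the series still sits at a limit, not a number: the limit of > 25 mg/kg in this assay, at which 2 of the 3 values shown sit.

As far as these compounds go, how far compound 1 lies past its limit stays open. So does what an amine or a carboxylic acid on the same aromatic carbon would give in this assay.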